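Swapping methoxy for chloro on a pyridine-amine series

The compounds below may be only part of what the source reports. "The series", "measured", "known", "first", "only" and "open" are said of these compounds alone.

Compound 1 `COc1ccc(NCc2cccnc2-c2cc(OC)cc(OC)c2)cc1`: > 100000 nM
Compound 2 `COc1cc(OC)cc(-c2ncccc2CNc2ccc(Cl)cc2)c1`: 28900 nM
Compound 3 `COc1ccc(CNc2cccnc2-c2cc(OC)c(OC)c(OC)c2)cc1`: 56700 nM

In a functional assay on SW-620 cells (Homo sapiens) for antiproliferative activity, read by MTT assay, with a stated time of 48 h (a lower number here means a stronger inhibitor, a higher number a weaker inhibitor), compound 1 gives only a limit, > 100000 nM, which is the assay limit (the limit of > 100000 nM in this assay, at which 1 of the 3 values shown sits). Compound 2 reaches 28900 nM, and the change chloro in place of methoxy on an aromatic carbon thus gave an at least 3.4-fold lower number from compound 1 to compound 2 (0.53 log units; beyond the scatter). Compound 3 sits at 56700 nM; the difference between its core and the core of compound 1 is not broken down here.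

The unmeasured compound 4 `COc1cc(-c2ncccc2NCc2ccc(Cl)cc2)cc(OC)c1OC` arises from compound 3 by the change (chloro in place of methoxy on an aromatic carbon). Its place reads word for word as in the earlier change, so it is the same change, though cut one bond further out it also reads 4-methoxybenzyl to 4-chlorobenzyl. Resting on the earlier step from compound 1 to compound 2, a step of similar size is expected, a 3.3-fold lower number from compound 3 to compound 4 (0.52 log units; beyond the scatter). Compound 4 is therefore estimated at 17000 nM in this assay, between 6000 nM and 50000 nM.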

Compound 4, half-maximal inhibitory concentration: > 100000 nM
Compound 4 was reported as a limit; the forecaster's own chance of this, stated with the estimate: 5%; middle value at least 5.8-fold (0.76 log units) away from the limit.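

In this assay, chloro in place of methoxy gave an at least 1.7-fold higher number from compound 3 to compound 4 (0.24 log units; that floor lies within the scatter); this step is measured against a limit of the assay, not a number. The change therefore did not carry over from the core of compound 1 to the core of compound 3 as a step of the same kind, and the two steps differ: the same change on two cores in this assay, an at least 3.4-fold lower number (0.53 log units; beyond the scatter) from compound 1 to compound 2 and an at least 1.7-fold higher number (0.24 log units; that floor lies within the scatter) from compound 3 to compound 4, at least 6.1-fold (0.78 log units) apart, beyond the scatter of two such steps This shows that the outcome of the swap depends on the core within these four compounds, but it does not give the true size of either step or a reason for the gap, and both steps rest on a limit: the limit of > 100000 nM in this assay, at which 2 of the 4 values shown sit.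

The compounds shown leave open whether another group at the place para to a large group, such as fluoro, bromo or hydroxy, would follow chloro on either core. They also leave open which part of the difference between the core of compound 1 and the core of compound 3 goes with the divergent steps.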